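The source may hold more compounds than are shown below. What is called first, only, known or untested is meant among the compounds shown, and "the series" means these compounds.

Compound 1 `CCNC(=O)Nc1nc2cc(-c3cnc(N4CCC(C)(C(=O)O)CC4)nc3)cc(-c3ccccn3)c2s1` and compound 2 `CCNC(=O)Nc1nc2cc(-c3cnc(N4CCC(C(=O)O)(C(F)(F)F)CC4)nc3)cc(-c3ccccn3)c2s1` share one core and differ only at a saturated ring carbon. In a physicochemical assay for solubility, read by turbidimetry, in phosphate buffer, with a stated time of 24 h, at pH 7.4 (on this read-out higher numbers stand for higher solubility and lower numbers for lower solubility), compound 1 gives > 800 ug/mL, which is a limit of the assay and not a number. In this assay compound 2 likewise gives > 800 ug/mL, again a limit. The step that the two limits leave unreadable from compound 1 to compound 2 is thus not readable in size, since both values sit at the limit of > 800 ug/mL in this assay, at which 2 of the 2 values shown sit. Compound 2 therefore stands at the top of what this assay can report, with no number of its own.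

Compound 3 `CCNC(=O)Nc1nc2cc(-c3cnc(N4CCC(N)(C(=O)O)CC4)nc3)cc(-c3ccccn3)c2s1` has not been measured in this assay. It differs from compound 2 by amino in place of trifluoromethyl on a saturated ring carbon. Going by the values given here, the only measured step at this position is a step that the two limits leave unreadable from compound 1 to compound 2, and its size stays hidden by the two limits, so no measured step gives a direction for the change to compound 3. In this assay the step from compound 2 to compound 3 is expected to be a step that the limit leaves unreadable from compound 2 to compound 3. Compound 3 is estimated to give 1000 ug/mL in this assay, within a range from 400 ug/mL to 3000 ug/mL, and is expected most likely to be reported again only as a limit.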

Compound 3, solubility: 25 ug/mL
Estimate against measurement, compound 3: 40-fold (1.60 log units) above; measured number outside the range, below it.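

In this assay, this ring carbon is not a silent position: amino in place of trifluoromethyl gives an at least 32-fold lower number from compound 2 to compound 3 (1.50 log units; beyond the scatter) and amino in place of methyl gives an at least 32-fold lower number from compound 1 to compound 3 (1.50 log units; beyond the scatter). Compound 3 is the only one of the three with a number of its own, which shows that a change at this carbon alone can bring the read-out down from the top of the reportable range while the shared core and the carboxylic acid stay the same. Methyl and trifluoromethyl remain unseparated, and the step between compound 1 and compound 2 still cannot be read: the limit of > 800 ug/mL in this assay, at which 2 of the 3 values shown sit.

As far as these compounds go, compound 1 and compound 2 are both limits and not numbers, so how far the real gaps to compound 3 reach past the printed steps remains open. From the compounds shown here alone, it is also open whether a hydroxyl, an aminomethyl or a dimethylamino group on this saturated ring carbon would stay at the limit with methyl and trifluoromethyl or fall toward compound 3.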